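A few compounds are considered here, and "the series" means these few. Any claim that something is new, unique, unknown or untested is made for them only; others in the source may bear on it.

Compound 1 `NC(=O)c1ccccc1NC(=O)COc1ccccc1`: 8900 nM
Compound 2 `NC(=O)c1cc(Cl)ccc1NC(=O)COc1ccccc1`: 1300 nM
Compound 3 `NC(=O)c1cc(I)ccc1NC(=O)COc1ccccc1`: 160 nM

In a functional assay on K562 cells (Homo sapiens) for inhibition, read by trypan blue exclusion, with a stated time of 24 h (on this read-out higher numbers stand for weaker inhibition and lower numbers for stronger inhibition), compound 3 gives the lowest of the three numbers, 160 nM. The next structure, compound 4 `Cc1ccc(NC(=O)COc2ccccc2)c(C(N)=O)c1`, is reached by methyl in place of iodo on an aromatic carbon. Within the data shown here, no methyl compound has been measured. The nearest evidence is the halogen steps: a 6.8-fold lower number from compound 1 to compound 2 (0.84 log units; beyond the scatter), then an 8.1-fold lower number from compound 2 to compound 3 (0.91 log units; beyond the scatter), which add up to a 56-fold lower number from compound 1 to compound 3 (1.75 log units; beyond the scatter). Giving up the iodo should therefore forfeit much of that large step, with methyl expected to land near the values of the hydrogen and chloro compounds. The expected change is a 16-fold higher number from compound 3 to compound 4 (1.19 log units; beyond the scatter), a clearly higher number and beyond the scatter. Compound 4 is estimated at 2500 nM, with an expected range of 800 nM to 8000 nM.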

Compound 4, half-maximal inhibitory concentration: 4700 nM
Beside the measured number, compound 4's estimate is 1.9-fold (0.27 log units) below it, and the stated range covers the measured number.
By their numbers in this assay, from the lowest: compound 3; then compound 2; then compounds 4 and 1 (each within the scatter of the next).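

In this assay, methyl on this aromatic carbon does not keep the halogen gain: the change gives a 29-fold higher number from compound 3 to compound 4 (1.47 log units; beyond the scatter) and a 3.6-fold higher number from compound 2 to compound 4 (0.56 log units; beyond the scatter). Against hydrogen it gives a 1.9-fold lower number from compound 1 to compound 4 (0.28 log units; within the scatter), so although iodo and methyl each count one heavy atom, filling this place with one heavy atom does not alone match the iodo result. Nothing available here explains this difference.

Open, from the compounds shown here alone, is where bromo, ethyl, an amine or a carboxylic acid at this position would fall. Also open, going by these compounds, is whether iodo gives a similar step elsewhere on the shared core.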